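Changing the Aryl Group on the Saturated Ring Carbon

The compounds below may be only part of what the source reports. "The series", "measured", "known", "first", "only" and "open" are said of these compounds alone.

Compound 1 `CC1=C(C(=O)Nc2ccc([N+](=O)[O-])cc2)C(c2ccc(Br)cc2)N=C(SCc2cccc(Cl)c2)N1` gives 2.6% in a functional assay on the whole organism (artery, strain albino) with Rattus norvegicus as the target, with a stated time of 720 min, at a dose of 10 mg/kg by the oral route; on this read-out higher numbers stand for more inhibition at the one dose given (going by the name of the read-out) and lower numbers for less inhibition.
Compound 2 `CC1=C(C(=O)Nc2ccc([N+](=O)[O-])cc2)C(c2ccc(Br)cc2)N=C(SCc2ccc(Cl)cc2)N1` gives 29.4% in this assay.
Compound 3 `CC1=C(C(=O)Nc2ccc([N+](=O)[O-])cc2)C(c2ccc(Br)cc2)N=C(SCc2ccc(F)cc2)N1` gives 27.3% in this assay.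

Among these three numbers compound 3 stands second highest. Compound 2 lies within the scatter of it, a number 2.1 percentage points lower from compound 2 to compound 3 (within the scatter), while compound 1 lies clearly below, a number 24.7 percentage points higher from compound 1 to compound 3 (beyond the scatter). Compound 4 `CC1=C(C(=O)Nc2ccc([N+](=O)[O-])cc2)C(c2cccc([N+](=O)[O-])c2)N=C(SCc2ccc(F)cc2)N1` is not yet measured; it differs from compound 3 in one place: 3-nitrophenyl in place of 4-bromophenyl on a saturated ring carbon.

The measured steps all concern the group on the sulfur, namely a number 26.8 percentage points higher from compound 1 to compound 2 (beyond the scatter), a number 24.7 percentage points higher from compound 1 to compound 3 (beyond the scatter) and a number 2.1 percentage points lower from compound 2 to compound 3 (within the scatter). None of them touches the saturated ring carbon that changes here, so none bears directly on the step to compound 4. They show only that changing one aromatic substituent in this series can move the read-out modestly, or not beyond the scatter at all. Going by the values given here, with no direct precedent for swapping 4-bromophenyl for 3-nitrophenyl, the direction of the step is open, and a wide range is appropriate.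

The estimate for compound 4 in this assay is 22%, with a range from 2% to 45%. This estimate corresponds to an expected step of a number 5.3 percentage points lower from compound 3 to compound 4 (within the scatter), an expectation that stays uncertain in direction.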

Compound 4, a percentage reported as inhibition, in the whole organism at one dose (the size of the read-out at that dose, not a potency): 20.1%
For compound 4 the middle estimate is 1.9 percentage points above the measured one; the range from low to high includes it.
By their numbers in this assay, from the lowest: compound 1; then compounds 4, 3 and 2 (each within the scatter of the next).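

Going by these compounds alone, this is the first measured change on the saturated ring carbon, since the earlier steps all concerned the group on the sulfur. Putting 3-nitrophenyl in place of 4-bromophenyl there gives a number 7.2 percentage points lower from compound 3 to compound 4 (within the scatter) in this assay and so shows that, with the (4-fluorobenzyl)sulfanyl group kept in place, this swap of aryl groups produces no difference that can be told apart from the scatter, even though both the substituent and its place on the aromatic ring change in one step. No supporting measurement is available to explain this result or to show whether the two groups behave alike for the same underlying reason.

Going by these compounds, because substituent and ring placement changed together, their separate contributions remain unknown, and a 3-bromophenyl or 4-nitrophenyl group would be needed to pull them apart. On these data alone, it also remains open how this carbon would respond to an unsubstituted phenyl, a 4-methoxyphenyl, a 4-aminophenyl or a non-aromatic cyclohexyl group, and whether the outcome would hold with a different group on the sulfur.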